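Thiophene for Phenyl on a Shared Core

The source may report more compounds than this note shows. Statements on the series, on what has been measured and on what is new or still open speak of the compounds shown alone.

Three compounds share one core and differ only in the group on one aromatic carbon of it. Compound 1 `CCCCCc1cc2nn(-c3ccccc3)cc2cn1` gives 2100 nM in a functional assay on K562 cells (Homo sapiens) for inhibition, read by fluorescence, with a stated time of 72 h; on this read-out higher numbers stand for weaker inhibition of growth and lower numbers for stronger inhibition of growth. Compound 2 `CCCCc1cc2nn(-c3ccccc3)cc2cn1` gives 6700 nM in this assay, and compound 3 `c1ccc(-c2cc3nn(-c4ccccc4)cc3cn2)cc1` gives 3400 nM. Among these numbers compound 3 stands second highest; its nearest neighbour is compound 1, and the step of a 1.6-fold higher number from compound 1 to compound 3 (0.21 log units; within the scatter) lies within the scatter, as does the step of a 2.0-fold lower number from compound 2 to compound 3 (0.29 log units; within the scatter). Going by the values given here, only the step of a 3.2-fold higher number from compound 1 to compound 2 (0.50 log units; beyond the scatter) reaches beyond it.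

Compound 4 `c1ccc(-n2cc3cnc(-c4ccsc4)cc3n2)cc1` is not yet measured. The change from compound 3 to compound 4 is thiophen-3-yl in place of phenyl on an aromatic carbon. Among the compounds with values here, no measured step exchanges one aromatic group for another; the two steps that end at compound 3 replace a chain by phenyl, and both stay within the scatter. Nothing in the data therefore points to a change of any size from this exchange. The step expected is a 1.1-fold lower number from compound 3 to compound 4 (0.05 log units; within the scatter), none beyond the scatter. Compound 4 is estimated at 3000 nM in this assay, within a range from 1200 nM to 8000 nM.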

Compound 4, concentration for 50% growth inhibition: 8300 nM
For compound 4 the middle estimate is 2.8-fold (0.44 log units) below the measured one, outside the stated range (above it).
By their numbers in this assay, from the lowest: compounds 1, 3, 2 and 4 (each within the scatter of the next, the first and the last beyond it).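

At this aromatic carbon, next to the ring nitrogen, the exchange of one aromatic ring for another proved not to be neutral: in this assay there is a 2.4-fold higher number from compound 3 to compound 4 (0.39 log units; beyond the scatter) when thiophen-3-yl, a five-membered aromatic ring with one hetero atom, replaces phenyl, a six-membered aromatic ring of carbon only. The position therefore distinguishes between these two aromatic groups, and thiophen-3-yl does not stand with pentyl either, given a 4.0-fold higher number from compound 1 to compound 4 (0.60 log units; beyond the scatter) on the same read-out, while the comparison with butyl shows only a 1.2-fold higher number from compound 2 to compound 4 (0.09 log units; within the scatter) and so separates those two groups no more than the scatter allows. Nothing available here accounts for the difference between phenyl and thiophen-3-yl.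

The compounds shown do not tell whether the step follows the ring size or the sulfur atom, and a furan-3-yl, thiophen-2-yl or pyridinyl group at this carbon would be needed to separate the two. They also leave open how a phenyl ring carrying a methoxy group or a fluorine atom, or a chain longer than pentyl, would read in this assay on the shared core.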